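Alkyne tail variation on a shared uracil-like core

The source may report more compounds than this note shows. Statements on the series, on what has been measured and on what is new or still open speak of the compounds shown alone.

Of the compounds shown here, two have been measured in a functional assay on HeLa cells (Homo sapiens) for antiproliferative activity, read by MTT assay, with a stated time of 72 h; on this read-out higher numbers stand for weaker inhibition and lower numbers for stronger inhibition. Compound 1 `O=c1[nH]c(=O)n(CCC(CO)CO)cc1C#Cc1cc(F)cc(F)c1` carries a 3,5-difluorophenyl on the triple-bonded carbon and in this assay compound 1 gives 31200 nM. Compound 2 `CCCCCC#Cc1cn(CCC(CO)CO)c(=O)[nH]c1=O` carries a pentyl in that place and in this assay compound 2 gives 76300 nM. The only step that connects them, a 2.4-fold higher number from compound 1 to compound 2 (0.39 log units; beyond the scatter), shows that the change from the aryl to the straight chain went to a higher number, and compound 2 therefore holds the highest of the two numbers shown.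

Compound 3 `CC(C)(C)C#Cc1cn(CCC(CO)CO)c(=O)[nH]c1=O` is the next member: tert-butyl in place of pentyl on a triple-bonded carbon. No measured step among these compounds compares one alkyl with another on the triple-bonded carbon, so the one step known, from the aryl to the pentyl, bears on it only loosely, and it was modest. Compound 3 is therefore expected to sit close to compound 2, with at most a small shift to a higher number in this assay, as a 1.2-fold higher number from compound 2 to compound 3 (0.07 log units; within the scatter) expresses. The estimate for compound 3 in this assay is 90000 nM, within a range of 35000 nM to 250000 nM.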

Compound 3, half-maximal inhibitory concentration: > 100000 nM
Compound 3: no number, only a limit (the forecaster's own chance of this, stated with the estimate: 20%); at least 1.1-fold (0.04 log units) between middle value and limit.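

In this assay compound 3 gives no number, only a limit: the limit of > 100000 nM in this assay, at which 1 of the 3 values shown sits. Swapping one alkyl group for another on the triple-bonded carbon gives an at least 1.3-fold higher number from compound 2 to compound 3 (0.11 log units; that floor lies within the scatter), so this floor does not set the pentyl and tert-butyl groups apart, and their true order stays unsettled. Against the aryl group the picture is firmer: an at least 3.2-fold higher number from compound 1 to compound 3 (0.50 log units; beyond the scatter), and together with a 2.4-fold higher number from compound 1 to compound 2 (0.39 log units; beyond the scatter) this means that both alkyl groups give higher numbers than the 3,5-difluorophenyl, which leaves compound 1 with the lowest value of the three in this small set.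

On these data alone, it remains open whether an unsubstituted phenyl, a cyclopropyl or a chain ending in a hydroxyl or an amine on the triple-bonded carbon would fall nearer to compound 1 or nearer to the alkyl compounds, and how much of the value of compound 1 depends on its two fluorines. The compounds shown also give no true size for the difference between compound 2 and compound 3, since only a floor is available for that step.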